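Chloro on the pendant phenyl: cytotoxicity expected to remain unmeasurable

The source may report more compounds than this note shows. Statements on the series, on what has been measured and on what is new or still open speak of the compounds shown alone.

Compound 1, `O[C@@H]1Cc2ccccc2N[C@H](c2ccccc2)C1`, was tested in an ADME assay on THP-1 cells (Homo sapiens) for cytotoxicity, read by MTT assay, with a stated time of 72 h; a lower number here means that less compound is tolerated, a higher number that more compound is tolerated. In this assay compound 1 gives > 300000 nM, which is a limit of the assay rather than a number. Compound 2, `O[C@@H]1Cc2cc(F)ccc2N[C@H](c2ccccc2)C1`, carries fluoro in place of hydrogen on an aromatic carbon of the core. In this assay compound 2 also gives only a limit, > 300000 nM. The step that the two limits leave unreadable from compound 1 to compound 2 therefore cannot be read, because of the limit of > 300000 nM in this assay, at which 2 of the 2 values shown sit. Compound 3, `O[C@@H]1Cc2ccccc2N[C@H](c2ccc(Cl)cc2)C1`, differs from compound 1 by chloro in place of hydrogen on an aromatic carbon. For the measured compounds named here, no measured step touches the pendant phenyl, so the only guide is that both compounds known so far sit at the same limit. For compound 3 the step of an at least 1.2-fold lower number from compound 1 to compound 3 (0.07 log units; that floor lies within the scatter) is expected to stay within the scatter. Compound 3 is therefore estimated to give 250000 nM in this assay, with a range from 50000 nM to 600000 nM, most likely again as a limit.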

Compound 3, half-maximal cytotoxic concentration: 114000 nM
Compound 3: the middle estimate sits 2.2-fold (0.34 log units) above what was measured; the measured number falls inside the stated range.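

Chloro on an aromatic carbon of the pendant phenyl gives the first readable step among these compounds: in this assay the change gives an at least 2.6-fold lower number from compound 1 to compound 3 (0.42 log units; beyond the scatter). The fluoro step on the core cannot be read, whereas this step shows that a single chloro at this place is enough to bring a measured number, with less compound tolerated than for compound 1. The size of the step remains a floor and not a full measure because compound 1 is known only as a limit: the limit of > 300000 nM in this assay, at which 2 of the 3 values shown sit.

As far as these compounds go, what a methoxy group or an amine at this same place would give remains open. From the compounds shown here alone, it is also open whether the step belongs to chloro itself or to this position, since chloro elsewhere on the shared core has no value here.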